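The source may hold more compounds than are shown below. What is called first, only, known or untested is meant among the compounds shown, and "the series" means these compounds.

Three compounds share one core and differ only in the group attached to one aromatic carbon. Compound 1 `COc1cc[nH]c1/C=C1\C(=O)Nc2ccc([N+](=O)[O-])c(N[C@H]3CC[C@H](O)CC3)c21` carries a (4-hydroxycyclohexyl)amino group, and in a functional assay on MDA-MB-435 cells (Homo sapiens) for antiproliferative activity, read by MTT assay, with a stated time of 5 days (on this read-out higher numbers stand for weaker inhibition and lower numbers for stronger inhibition), compound 1 gives 8550 nM. Compound 2 `COc1cc[nH]c1/C=C1\C(=O)Nc2ccc([N+](=O)[O-])c(N3CCC(O)CC3)c21` carries a 4-hydroxypiperidin-1-yl group; in this assay compound 2 gives 46 nM, a 190-fold lower number from compound 1 to compound 2 (2.27 log units; beyond the scatter). Compound 3 `COc1cc[nH]c1/C=C1\C(=O)Nc2ccc([N+](=O)[O-])c(N3CC[C@@H](N)C3)c21` carries a 3-aminopyrrolidin-1-yl group, and in this assay compound 3 is reported only as < 10 nM. That value is a limit of the assay, not a number, the one described as the limit of < 10 nM in this assay, at which 1 of the 3 values shown sits. Compound 3 thus stands at the strong end of the three, with an at least 850-fold lower number from compound 1 to compound 3 (2.93 log units; beyond the scatter) and an at least 4.6-fold lower number from compound 2 to compound 3 (0.66 log units; beyond the scatter). Compound 4 `COc1cc[nH]c1/C=C1\C(=O)Nc2ccc([N+](=O)[O-])c(-n3ccnc3)c21` alters this same group: 1H-imidazol-1-yl in place of 3-aminopyrrolidin-1-yl on an aromatic carbon. The two steps that reach compound 3 both favour a nitrogen-linked ring, yet neither measured step swaps a saturated ring bearing a hydrogen-bond donor for an aromatic one without it, so an expected modest rise, an at least 6.0-fold higher number from compound 3 to compound 4 (0.77 log units; beyond the scatter), is the estimate for this change. Compound 4 is therefore expected to give about 60 nM, between 12 nM and 400 nM.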

Compound 4, half-maximal inhibitory concentration: > 30000 nM
Compound 4 ended at the assay's limit; the forecaster's own chance of this, stated with the estimate: 15%; at least 500-fold (2.69 log units) between middle value and limit.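

Compound 4 stands at a limit of this assay, which is not a number: the limit of > 30000 nM in this assay, at which 1 of the 4 values shown sits. On this aromatic carbon, ortho to a nitro group, the 1H-imidazol-1-yl group falls far short of both saturated rings (an at least 3000-fold higher number from compound 3 to compound 4 (3.47 log units; beyond the scatter)) and (an at least 650-fold higher number from compound 2 to compound 4 (2.81 log units; beyond the scatter)), and it also falls short of the (4-hydroxycyclohexyl)amino group (an at least 3.5-fold higher number from compound 1 to compound 4 (0.54 log units; beyond the scatter)). Compound 2 and compound 3 suggested that a ring joined through its nitrogen goes with strong inhibition here, but compound 4 goes against that pattern, so this link alone is not enough.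

Compound 4 differs from compound 3 both in having an aromatic ring and in lacking a hydrogen-bond donor, and the compounds shown cannot separate these two changes. A plain pyrrolidin-1-yl ring with no amine, or an imidazole ring carrying an aminomethyl group, would be needed to tell them apart.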